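This account rests on a few compounds, and the source may have more. Where it says the series, first, only, none or still open, it means among the compounds named here.

Measured in an assay on microsomes from liver for inhibition of 3-hydroxy-3-methylglutaryl-coenzyme A reductase (Rattus norvegicus); on this read-out lower numbers stand for stronger inhibition and higher numbers for weaker inhibition: compound 1 `CC(C)c1c(C(=O)N(C)Cc2cccc(F)c2)nn(-c2ccc(F)cc2)c1CC[C@@H](O)C[C@@H](O)CC(=O)O` gives 4.1 nM; compound 2 `CCN(Cc1ccccc1)C(=O)c1nn(-c2ccc(F)cc2)c(OC[C@@H](O)C[C@@H](O)CC(=O)O)c1C(C)C` gives 14 nM; compound 3 `CC(C)c1c(C(=O)NCc2cccc(F)c2F)nn(-c2ccc(F)cc2)c1OC[C@@H](O)C[C@@H](O)CC(=O)O` gives 2 nM.

Compound 3 holds the lowest number of the three, with compound 1 nearest and compound 2 furthest away. Among the measured compounds shown here, the only single-place step among the measured compounds runs a 7.0-fold lower number from compound 2 to compound 3 (0.85 log units; beyond the scatter), and it concerns the same carbonyl position that is changed next. Compound 4 `CC(C)c1c(C(=O)N2CCC[C@H](c3ccccc3)C2)nn(-c2ccc(F)cc2)c1OC[C@@H](O)C[C@@H](O)CC(=O)O` differs from compound 3 by 3-phenylpiperidin-1-yl in place of (2,3-difluorobenzyl)amino on a carbonyl carbon. For the measured compounds named here, compound 4 thus leaves the group that brought the gain of that measured step and takes up a ring-bound amide substituent with no direct precedent; compound 1 carries another amide substituent but also another link to the dihydroxy acid chain, so its number cannot be read as a step. On the measured step alone, moving away from (2,3-difluorobenzyl)amino is expected to cost some potency in this assay, though a smaller loss than the full gain is expected, since the phenyl ring is retained. The estimated step of a 4.0-fold higher number from compound 3 to compound 4 (0.60 log units; beyond the scatter) is therefore expected to lie beyond the scatter. Compound 4 is expected to give about 8 nM, within a range of 3 nM to 25 nM.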

Compound 4, half-maximal inhibitory concentration: 4.8 nM
Beside the measured number, compound 4's estimate is 1.7-fold (0.22 log units) above it; low and high end bracket the measured number.
By their numbers in this assay, from the lowest: compound 3; then compounds 1 and 4 (each within the scatter of the next); then compound 2.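

In this assay, replacing (2,3-difluorobenzyl)amino with 3-phenylpiperidin-1-yl on the carbonyl carbon gives a 2.4-fold higher number from compound 3 to compound 4 (0.38 log units; beyond the scatter), so this position accepts a ring-bound amide substituent at only a modest cost. The same substituent in place of benzyl(ethyl)amino gives a 2.9-fold lower number from compound 2 to compound 4 (0.46 log units; beyond the scatter), which places compound 4 between the two earlier compounds with the same core and shows that the choice among substituents lacking the amide hydrogen also moves the number, since neither compound 2 nor compound 4 has that hydrogen. No measurement here explains why these substituents rank as they do.

The compounds shown leave open how much of the difference comes from the piperidine ring and how much from its phenyl group, a question that plain piperidin-1-yl or 4-phenylpiperidin-1-yl would address. They also leave open whether the opposite configuration at the defined stereocentre, or fluorine atoms on the phenyl ring of 3-phenylpiperidin-1-yl, would change the number in this assay.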